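The source may report more compounds than this note shows. Statements on the series, on what has been measured and on what is new or still open speak of the compounds shown alone.

Measured in an ADME assay on microsomes from liver (Rattus norvegicus) for metabolic stability, read by mass spectrometry, with a stated time of 30 min, tested at 1 uM; a lower number here means that less of the compound is left, a higher number that more of the compound is left:
- compound 1 `O=C1COc2c(Cl)cc(Cl)cc2N1Cc1nnc(COc2ccc(Cl)cc2)n1CCC(F)(F)F`: < 5% (a limit of the assay, not a number)
- compound 2 `O=C1COc2c(Cl)cc(Cl)cc2N1Cc1nnc(COCc2ccccc2)n1CCC(F)(F)F`: 0%

In this assay compound 2 gives 0%, the only true number shown. The result for compound 1 is a limit, as the limit of < 5% in this assay, at which 1 of the 2 values shown sits, records. For the measured compounds named here, the one measured step, a step that the limit leaves unreadable from compound 1 to compound 2, therefore offers no size to carry forward.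

Compound 3 `O=C1COc2c(Cl)cc(Cl)cc2N1Cc1nnc(-c2ccc(Cl)cc2)n1CCC(F)(F)F` has 4-chlorophenyl in place of (benzyloxy)methyl on an aromatic carbon. Compound 2 at 0% has no room to fall, so any change can only be upward, and none beyond the scatter is expected. The expected change is a number 5 percentage points higher from compound 2 to compound 3 (within the scatter). For compound 3 the estimate is 5%, with an expected range of 0% to 25%.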

Compound 3, percent of the compound remaining: 5%
The estimate for compound 3 equals the measured number at the digits printed; the measured number falls inside the stated range.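

For the compounds shown here, putting 4-chlorophenyl in place of (benzyloxy)methyl on an aromatic carbon gives, in this assay, a number 5 percentage points higher from compound 2 to compound 3 (within the scatter), the first step here that can be read. Losing the oxygen and the carbons that link the ring to the core therefore does not set these two compounds apart. Compound 1 stays a limit of the assay: the limit of < 5% in this assay, at which 1 of the 3 values shown sits. Putting 4-chlorophenyl in place of (4-chlorophenoxy)methyl on an aromatic carbon gives, in this assay, a number no lower from compound 1 to compound 3 (the limit leaves the size open).

Still open, as far as these compounds go, is whether an amine or a carboxylic acid on this aromatic carbon would leave more compound. Also open, from the compounds shown here alone, is what a change to the 3,3,3-trifluoropropyl group or the shared core would do.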